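The source may report more compounds than this note shows. Statements on the series, on what has been measured and on what is new or still open speak of the compounds shown alone.

Compound 1 `Fc1cc(-n2nnc(-c3ccccn3)n2)cc(-n2ccc3ccncc32)c1`: 25 nM
Compound 2 `Fc1cc(Cc2cccnc2)cc(-n2nnc(-c3ccccn3)n2)c1`: 38 nM

For the measured compounds named here, in an assay for binding affinity to metabotropic glutamate receptor 5 (Rattus norvegicus) (on this read-out higher numbers stand for weaker inhibition and lower numbers for stronger inhibition), compound 2 gives 38 nM, the highest of the two numbers measured so far; compound 1 gives 25 nM, and the step of a 1.5-fold higher number from compound 1 to compound 2 (0.18 log units; within the scatter) lies within the scatter, so the two compounds cannot be ranked against each other. Compound 3 `CN(c1cccnc1)c1cc(F)cc(-n2nnc(-c3ccccn3)n2)c1` differs from compound 2 in one place: methyl(pyridin-3-yl)amino in place of (pyridin-3-yl)methyl on an aromatic carbon. Going by the values given here, the only measured step, a 1.5-fold higher number from compound 1 to compound 2 (0.18 log units; within the scatter), exchanged a different group on that aromatic carbon and produced nothing beyond the scatter; it gives no direct precedent for the methyl(pyridin-3-yl)amino group. With nothing in the data pointing either way, a step in this assay within the scatter is expected for compound 3. The step expected from this reading is a 1.2-fold higher number from compound 2 to compound 3 (0.07 log units; within the scatter). Compound 3 is therefore estimated at 45 nM, with a range from 15 nM to 150 nM.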

Compound 3, inhibition constant: 30 nM
Compound 3: the middle estimate sits 1.5-fold (0.18 log units) above what was measured; the measured number falls inside the stated range.
By their numbers in this assay, from the lowest: compounds 1, 3 and 2 (each within the scatter of the next).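

In this assay, methyl(pyridin-3-yl)amino in place of (pyridin-3-yl)methyl gives a 1.3-fold lower number from compound 2 to compound 3 (0.10 log units; within the scatter), so on this aromatic carbon, meta to a fluoro group, the entering group's additional heavy atoms and hydrogen-bond acceptors leave no readable mark on the number. The comparison with the larger group of compound 1 gives a 1.2-fold higher number from compound 1 to compound 3 (0.08 log units; within the scatter), which means that all three groups at this place, whatever their size and ring count, now lie within the scatter of one another. Nothing available explains why these groups read alike.

The compounds shown leave open whether a group without a pyridine ring, such as a phenyl ring, would read the same. They also leave open whether a carboxylic acid, a primary amine or a longer chain at this place would move the number beyond the scatter.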